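The compounds below may be only part of what the source reports. "The series", "measured", "known", "first", "only" and "open" are said of these compounds alone.

Three compounds share one core and differ only in the group that sits on a saturated chain carbon bound to an aromatic carbon. Compound 1 `CCCCCCCCN1C(=O)[C@H](Cc2ccc(-c3cccc(CN(CCCC)C(C)=O)c3)cc2)N(C)C(=O)[C@@H]1C` carries an acetyl there and in a functional assay for agonist activity at follicle-stimulating hormone receptor (Homo sapiens), read by a luciferase reporter (on this read-out higher numbers stand for an effect only at larger amounts of compound and lower numbers for an effect already at smaller amounts), compound 1 gives 14 nM. Compound 2 `CCCCCCCCN1C(=O)[C@H](Cc2ccc(-c3cccc(CN(CCCC)C(=O)OC)c3)cc2)N(C)C(=O)[C@@H]1C` carries a methoxycarbonyl and gives 2.7 nM. Compound 3 `CCCCCCCCN1C(=O)[C@H](Cc2ccc(-c3cccc(CN(CCCC)C(=O)NC)c3)cc2)N(C)C(=O)[C@@H]1C` carries a methylcarbamoyl and gives 1.2 nM. Compound 3 has the lowest number of the three, shown by a 2.3-fold lower number from compound 2 to compound 3 (0.35 log units; beyond the scatter) and by a 12-fold lower number from compound 1 to compound 3 (1.07 log units; beyond the scatter). Compound 4 `CCCCCCCCN1C(=O)[C@H](Cc2ccc(-c3cccc(CN(COC)C(C)=O)c3)cc2)N(C)C(=O)[C@@H]1C` alters two things at once: acetyl(methoxymethyl)amino in place of butyl(methylcarbamoyl)amino on a saturated chain carbon bound to an aromatic carbon. The carbonyl part of this move reverses a measured step, because a 12-fold lower number from compound 1 to compound 3 (1.07 log units; beyond the scatter) records the gain on going from acetyl to methylamino, while a 5.2-fold lower number from compound 1 to compound 2 (0.71 log units; beyond the scatter) places the methoxy variant between them. Going by the values given here, no measured pair speaks to butyl against methoxymethyl, so that part adds uncertainty without direction. The expected step therefore reads a 13-fold higher number from compound 3 to compound 4 (1.10 log units; beyond the scatter), climbing back toward the level of compound 1. Compound 4 is accordingly estimated at 15 nM, within 4 nM and 60 nM.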

Compound 4, half-maximal effective concentration: 9.7 nM
Compound 4: the middle estimate sits 1.5-fold (0.19 log units) above what was measured; the measured number falls inside the stated range.
By their numbers in this assay, from the lowest: compound 3; then compound 2; then compounds 4 and 1 (each within the scatter of the next).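

Going by these compounds alone, compound 4 gives the first reading of the chain on the amide-type nitrogen: with the acetyl kept, methoxy in place of propyl on a saturated chain carbon bound to an amide-type nitrogen gives a 1.4-fold lower number from compound 1 to compound 4 (0.16 log units; within the scatter) in this assay, so the two chains are not told apart here. The clearer steps, an 8.1-fold higher number from compound 3 to compound 4 (0.91 log units; beyond the scatter) and a 3.6-fold higher number from compound 2 to compound 4 (0.56 log units; beyond the scatter), both change the carbonyl group as well as the chain, so among these four compounds the numbers follow the carbonyl group and not the chain. Nothing available explains these differences.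

The compounds shown leave open whether methoxymethyl would match butyl with methylamino or methoxy on the carbonyl carbon. They also leave open how a longer chain or a terminal amine on the amide-type nitrogen would read.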